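The source may report more compounds than this note shows. Statements on the series, on what has been measured and on what is new or still open speak of the compounds shown alone.

Compound 1 `CC1CC(=O)N(CC(=O)N2CCN(c3cccc(Cl)c3)CC2)C1=O`: 100 mg/kg
Compound 2 `Cc1ccccc1N1CCN(C(=O)CN2C(=O)CC(C)C2=O)CC1`: 100 mg/kg

In a functional assay on the whole organism (strain CD1) with Mus musculus as the target, with a stated time of 0.5 h (on this read-out higher numbers stand for an effect only at larger amounts of compound and lower numbers for an effect already at smaller amounts), compound 2 gives 100 mg/kg, and it stands level with compound 1, its nearest measured neighbour; the step of no change at the digits printed from compound 1 to compound 2 (within the scatter) lies within the scatter. Compound 3 `CC1CC(=O)N(CC(=O)N2CCN(c3cccc(Cl)c3Cl)CC2)C1=O` has not yet been measured. It differs from compound 2 by 2,3-dichlorophenyl in place of 2-methylphenyl on an amine nitrogen in a ring. For the measured compounds named here, the one measured step bears on this: no change at the digits printed from compound 1 to compound 2 (within the scatter) shows that exchanging the group on the amine nitrogen in a ring left this assay unchanged. The step of no change at the digits printed from compound 2 to compound 3 (within the scatter) is therefore expected to stay within the scatter. Compound 3 is estimated at 100 mg/kg, with a range from 50 mg/kg to 200 mg/kg.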

Compound 3, minimum effective dose: 100 mg/kg
The estimate for compound 3 equals the measured number at the digits printed; the range from low to high includes it.
By their numbers in this assay, from the lowest: compounds 1, 2 and 3 (each within the scatter of the next).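

On the amine nitrogen in a ring, 2,3-dichlorophenyl in place of 2-methylphenyl gives no change at the digits printed from compound 2 to compound 3 (within the scatter) in this assay, and chloro in place of hydrogen on an aromatic carbon gives no change at the digits printed from compound 1 to compound 3 (within the scatter). So a second chloro group on the phenyl ring, and not only an exchange of one group for another, leaves this read-out where it was. No measurement on hand explains this flat result.

Still open, as far as these compounds go, is whether a group other than a substituted phenyl on that nitrogen, such as a pyridine ring or a benzyl group, would shift the minimum effective dose. Changes elsewhere on the shared core also remain open.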